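Enone series: ethoxy to isopentyloxy from compound 2

The source may hold more compounds than are shown below. What is called first, only, known or untested is meant among the compounds shown, and "the series" means these compounds.

Of the compounds shown here, three have been measured in a functional assay on HCT-8 cells (Homo sapiens) for antiproliferative activity, read by sulforhodamine B assay, with a stated time of 3 days; on this read-out higher numbers stand for an effect only at larger amounts of compound and lower numbers for an effect already at smaller amounts. Compound 1 `COC1=C(CC=C(C)C)C(=O)/C(=C(O)/C=C/c2ccccc2)C(=O)C1(CC=C(C)C)CC=C(C)C` gives 13.7 uM. Compound 2 `CCCC1=C(OCC)C(CCC)(CCC)C(=O)/C(=C(O)\C=C\c2ccccc2)C1=O` gives 5.6 uM, and compound 3 `CCCC1=C(OC)C(CCC)(CCC)C(=O)/C(=C(O)\C=C\c2ccc(Br)cc2)C1=O` gives 2.6 uM. Among these three numbers compound 2 stands second highest: compound 3 sits at a lower number, beyond the scatter, and compound 1 at a higher number, also beyond the scatter. Among the measured compounds shown here, no two measured compounds differ in one place only, so no single change carries a measured step.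

Compound 4 `CCCC1=C(OCCC(C)C)C(CCC)(CCC)C(=O)/C(=C(O)\C=C\c2ccccc2)C1=O` remains to be measured. It differs from compound 2 by isopropyl in place of hydrogen on a saturated chain carbon, two bonds along the chain from an oxygen on an unsaturated carbon. For the measured compounds named here, no measured pair isolates the change from ethoxy to isopentyloxy, so the expectation rests on compound 2 alone. The expected step of a 1.1-fold lower number from compound 2 to compound 4 (0.05 log units; within the scatter) amounts to no change beyond the scatter in either direction. Compound 4 is therefore estimated at 5 uM in this assay, within a range from 2 uM to 12 uM.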

Compound 4, concentration for half-maximal effect: 15.3 uM
Estimate against measurement, compound 4: 3.1-fold (0.49 log units) below, outside the stated range (above it).
By their numbers in this assay, from the lowest: compound 3; then compound 2; then compounds 1 and 4 (each within the scatter of the next).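

Ethoxy to isopentyloxy is the first change in this series that can be read as a single step: in this assay it gives a 2.7-fold higher number from compound 2 to compound 4 (0.44 log units; beyond the scatter), a modest step. This position, a saturated chain carbon two bonds along the chain from an oxygen on an unsaturated carbon, is therefore not indifferent to isopropyl in place of hydrogen, and the number moves upward with this larger group. Nothing at hand bears on the reason for this step.

The compounds shown leave open whether chain length or branching carries the step, which an unbranched pentyloxy chain on the same oxygen would help separate. A propoxy or butoxy group would show whether the number rises gradually along the chain or only with the full isopentyloxy group.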